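Shortening the Alkyl Chain on a Compound with Low Aldehyde Dehydrogenase Inhibition

The source may hold more compounds than are shown below. What is called first, only, known or untested is meant among the compounds shown, and "the series" means these compounds.

Three compounds sharing one core were measured in an assay on isolated protein for inhibition of aldehyde dehydrogenase 1A1 (Homo sapiens), read by spectrophotometry, tested at 10 uM; on this read-out lower numbers stand for less inhibition and higher numbers for more inhibition at the one concentration tested (going by the name of the read-out). Compound 1 `CC(C)Cn1c(CN2CCN(C(=O)C3CC3)CC2)nc2ccccc21` gives 13.1% in this assay, the lowest of the three numbers. Compound 2 `CC(C)CCn1c(OC2CCN(C(=O)c3ccco3)CC2)nc2ccccc21` gives 30.8%, and compound 3 `Cc1cccc(Cn2c(CN3CCN(C(=O)c4cccnc4)CC3)nc3ccccc32)c1` gives 24.5%. Both of these lie beyond the usual scatter above compound 1, compound 3 by the smaller margin and compound 2 by the larger. Within the data shown here, no pair among the three differs in a single place, so the numbers show only where each compound stands and not what any one change does.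

Compound 4 `CCn1c(CN2CCN(C(=O)C3CC3)CC2)nc2ccccc21` has not yet been measured in this assay. It differs from compound 1 in one place only: methyl in place of isopropyl on a saturated chain carbon bound to an aromatic nitrogen. Everything else in the molecule is kept as in compound 1.

Among the measured compounds shown here, no measured step of this kind exists among the three compounds, so the expectation for compound 4 rests on the value of compound 1 alone. Since compound 1 already sits low in this assay, the account expects compound 4 to remain close to it, with a step of a number 3.1 percentage points lower from compound 1 to compound 4 (within the scatter) that need not exceed the scatter. Compound 4 is therefore estimated at 10%, within a range from 0% to 25%.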

Compound 4, a percentage reported as inhibition, at one concentration (the size of the read-out at that concentration, not a potency): 20.8%
The estimate for compound 4 lay 10.8 percentage points below the measured number, within the range that was stated.
By their numbers in this assay, from the lowest: compounds 1, 4, 3 and 2 (each within the scatter of the next, the first and the last beyond it).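

In this assay, among these compounds, methyl in place of isopropyl on a saturated chain carbon bound to an aromatic nitrogen gives a number 7.7 percentage points higher from compound 1 to compound 4 (within the scatter), the first comparison that isolates a single place in the molecule. Read the other way, as isobutyl to ethyl, it shows that this chain can be cut back with the amide and the rest of compound 1 held constant, and that the two numbers stay within the scatter of each other, so this read-out does not separate the two chains at this position. Nothing measured bears on why the two compounds read as they do.

From the compounds shown here alone, what remains open is whether this position would separate other groups, such as a longer chain like hexyl, a benzyl group or a chain ending in a carboxylic acid or an amine. Going by these compounds, it is also open whether the same shortening would read alike with the furan carbonyl of compound 2 or the pyridine carbonyl of compound 3, since neither compound differs from compound 1 or compound 4 in one place only.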